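A few compounds are considered here, and "the series" means these few. Any claim that something is new, unique, unknown or untested is made for them only; others in the source may bear on it.

Compound 1 `COc1cc(C2=NN(C(C)=O)C(c3cccc(OC)c3OC)O2)cc(OC)c1OC` is one of three compounds examined in a functional assay on PC-3 cells (Homo sapiens) for antiproliferative activity, read by MTT assay, tested at 5 uM; on this read-out lower numbers stand for a weaker effect and higher numbers for a stronger effect at the one concentration tested. Under those conditions compound 1 gives 58.2%, the lowest of the three numbers. Compound 2 `COc1cc(C(=O)N/N=C/c2cccc(C(F)(F)F)c2)cc(OC)c1OC` gives 79.8% in this assay, and compound 3 `COc1cc(C(=O)N/N=C/c2ccc(F)cc2)cc(OC)c1OC` gives 82.8%, so both stand well beyond the usual scatter above compound 1, with compound 3 the furthest away.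

The not yet measured compound 4 `COc1cc(C2=NN(C(C)=O)C(c3cccc(C(F)(F)F)c3)O2)cc(OC)c1OC` keeps the core of compound 1 and differs from it in a single place: 3-(trifluoromethyl)phenyl in place of 2,3-dimethoxyphenyl on a saturated ring carbon. Within the data shown here, no step between two measured compounds repeats exactly this change, so its size can only be judged from the surrounding numbers. Compound 2 carries the same 3-(trifluoromethyl)phenyl on a different core, and since compound 2 gives 79.8% against compound 1 with 58.2%, the change is expected to push the number upward rather than downward, though a step within the scatter cannot be ruled out.

Compound 4 is therefore expected to give 68% in this assay, with a plausible range from 50% to 85%. That would mean an estimated rise a number 9.8 percentage points higher from compound 1 to compound 4 (within the scatter), modest in size, that leaves room for a measurement to decide whether it is real.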

Compound 4, a percentage reported as inhibition, at one concentration (the size of the read-out at that concentration, not a potency): 43.6%
Beside the measured number, compound 4's estimate is 24.4 percentage points above it; measured number outside the range, below it.
By their numbers in this assay, from the lowest: compound 4; then compound 1; then compounds 2 and 3 (each within the scatter of the next).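

In this assay, among these compounds, 3-(trifluoromethyl)phenyl in place of 2,3-dimethoxyphenyl on the saturated ring carbon gives a number 14.6 percentage points lower from compound 1 to compound 4 (beyond the scatter) and provides the first readable step at this position. On the core of compound 1, the position is therefore not indifferent to which of these two groups it carries: both have the same count of heavy atoms and one six-membered aromatic ring of carbon only, yet the number falls beyond the scatter. The counts do differ in hydrogen-bond acceptors, with two in the leaving group and none in the entering one, but no measurement at hand gives a reason for the fall.

From the compounds shown here alone, this single step exchanges both methoxy groups and introduces the trifluoromethyl group at once, so it remains open whether the fall comes from losing the former, gaining the latter or both. Also open, going by these compounds, is how this position would respond to an unsubstituted phenyl or to a phenyl carrying an amine or a carboxylic acid, and whether the order seen at the one concentration tested would hold at others.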